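This account rests on a few compounds, and the source may have more. Where it says the series, first, only, none or still open, it means among the compounds named here.

Measured so far:
- compound 1, `NS(=O)(=O)c1cccc(-c2nc(C(c3ccc(F)cc3)c3ccc(F)cc3)sc2CC(=O)O)c1`: 710 nM
- compound 2, `O=C(O)Cc1sc(C(c2ccc(F)cc2)c2ccc(F)cc2)nc1-c1ccnc(F)c1`: 4.7 nM

In an in vitro functional assay on HEK285-7 cells for antagonist activity at prostaglandin D2 receptor 2 (Homo sapiens), read by BRET and beta-arrestin recruitment (a higher number here means a weaker inhibitor, a lower number a stronger inhibitor), compound 1 gives 710 nM and compound 2 gives 4.7 nM. Among the measured compounds shown here, the one step between them, a 150-fold lower number from compound 1 to compound 2 (2.18 log units; beyond the scatter), exchanges the whole aryl group on the shared core. Compound 2 thus holds the lowest number of the two; its nearest neighbour, compound 1, sits a large and clearly resolved distance above it.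

Compound 3, `O=C(O)Cc1sc(C(c2ccc(F)cc2)c2ccc(F)cc2)nc1-c1cc(F)nc(F)c1`, keeps the core of compound 2 and differs from it only by fluoro in place of hydrogen on an aromatic carbon of the six-membered aromatic ring with one nitrogen, next to the ring nitrogen. For the measured compounds named here, no measured pair in this set isolates a single added fluoro on this ring: the step from compound 1 to compound 2 replaces the entire ring and gives no guide to a one-atom change within it. Without a bearing step, a change no larger than the scatter is expected in this assay, in either direction, so compound 3 is expected to give 6 nM, between 2 nM and 20 nM, a step of a 1.3-fold higher number from compound 2 to compound 3 (0.11 log units; within the scatter).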

Compound 3, half-maximal inhibitory concentration: 110 nM
The estimate for compound 3 lay 18-fold (1.26 log units) below the measured number; measured number above the stated range.
By their numbers in this assay, from the lowest: compound 2; then compound 3; then compound 1.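

In this assay, this position on the ring is sensitive to a very small change: a 23-fold higher number from compound 2 to compound 3 (1.37 log units; beyond the scatter), with a single fluoro entering next to the ring nitrogen, so the 2,6-difluoropyridin-4-yl group gives up most of what the 2-fluoropyridin-4-yl group showed. The fluoro-bearing ring still compares favourably with the group it replaced, with a 6.5-fold lower number from compound 1 to compound 3 (0.81 log units; beyond the scatter), a modest step that remains beyond the scatter, so the exchange of 3-sulfamoylphenyl for a fluorinated pyridine keeps part of its advantage even in the weaker of the two fluorinated forms. No supporting measurement accompanies these numbers to account for the loss on adding the second fluoro.

The compounds shown leave open whether the loss is specific to fluoro or would follow any group on that carbon, which a chloro or a methyl group there would help to separate. They also leave open what the existing fluoro contributes, which a pyridin-4-yl group carrying no fluoro on the same core would place on this scale.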